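This account rests on a few compounds, and the source may have more. Where it says the series, first, only, none or still open, it means among the compounds named here.

In a functional assay on Jurkat cells (Homo sapiens) for inhibition, read by CCK-8 assay, with a stated time of 48 h (a lower number here means a stronger inhibitor of growth, a higher number a weaker inhibitor of growth), neither measured compound gives a number. Compound 1 `CN1CCN(c2ccc(Nc3ncc(Cl)c(Nc4ccccc4)n3)nc2)CC1` gives > 100000 nM, which is a limit of the assay. Compound 2 `CN1CCN(c2ccc(Nc3ncc(Cl)c(NCc4ccc(F)cc4)n3)nc2)CC1` gives > 100000 nM, which is also only a limit. For the measured compounds named here, the series so far therefore offers (the limit of > 100000 nM in this assay, at which 2 of the 2 values shown sit), and compound 2 cannot be placed any more exactly than that. Going by the values given here, the one measured change, a step that the two limits leave unreadable from compound 1 to compound 2, has no readable size.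

Compound 3 `COc1ccc(CNc2nc(Nc3ccc(N4CCN(C)CC4)cn3)ncc2Cl)cc1` keeps the shared core and alters only the end of the benzyl group: methoxy in place of fluoro on an aromatic carbon. In words, methoxy stands in place of fluoro on an aromatic carbon, so that 4-fluorobenzyl becomes 4-methoxybenzyl. Among the compounds with values here, no measured step covers this exchange. The nearest one, a step that the two limits leave unreadable from compound 1 to compound 2, gives no size to carry over, so no step beyond the scatter is expected in this assay, and a report of a limit alone is the likeliest outcome. The expected change is a number no higher from compound 2 to compound 3 (the limit leaves the size open). For compound 3 the estimate is 100000 nM, with an expected range of 25000 nM to 150000 nM.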

Compound 3, concentration for 50% growth inhibition: 12900 nM
Compound 3: the middle estimate sits 7.8-fold (0.89 log units) above what was measured; the whole stated range lies above it.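

In this assay, methoxy in place of fluoro on an aromatic carbon, para to a large group, gives an at least 7.7-fold lower number from compound 2 to compound 3 (0.88 log units; beyond the scatter), so this end of the benzyl group can bring the series off its limit. Compound 3 gives a real number, 12900 nM. Set against the phenyl group of compound 1, the 4-methoxybenzyl group gives an at least 7.7-fold lower number from compound 1 to compound 3 (0.88 log units; beyond the scatter), whereas the step from compound 1 to compound 2 cannot be read, so the gain can be tied to 4-methoxybenzyl but not to a benzyl group as such. Both sizes are only lower bounds, since compound 1 and compound 2 give no number of their own: the limit of > 100000 nM in this assay, at which 2 of the 3 values shown sit.

The compounds shown leave open whether a hydroxyl, an ethoxy group or a dimethylamino group at the same place would give a lower number than compound 3 does, and so whether the oxygen or the whole methoxy group matters. They also leave open whether a methoxy group on the phenyl ring of compound 1 would lift that compound off its limit in this assay.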